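The source may report more compounds than this note shows. Statements on the series, on what has been measured and on what is new or still open speak of the compounds shown alone.

Measured so far:
Compound 1, `COC(=O)C1=C(C)NC(c2nccs2)=NC1(C)c1ccc(OC)cc1`, in a physicochemical assay for solubility, read by HPLC, in phosphate buffer, at pH 6.5 (a higher number here means a more soluble compound, a lower number a less soluble compound), gives 106 ug/mL.
Compound 2, `COC(=O)C1=C(CN2CCNCC2)NC(c2nccs2)=NC1(C)c1ccc(F)cc1`, in this assay gives 250 ug/mL.

Of these two numbers, compound 2 holds the higher one; its nearest neighbour is compound 1, whose number lies lower by a margin beyond the usual scatter. For the measured compounds named here, no two measured compounds differ in only one place, so no single step can be read from this pair; what the two values show is simply that compound 2 stands above compound 1.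

Compound 3, `COC(=O)C1=C(CN2CCCS2(=O)=O)NC(c2nccs2)=NC1(C)c1ccc(F)cc1`, has not yet been measured. It differs from compound 2 in one place: a group of 7 heavy atoms (3 carbon, 1 nitrogen, 2 oxygen, 1 sulfur; one five-membered non-aromatic ring with 2 hetero atoms) in place of a group of 6 heavy atoms (4 carbon, 2 nitrogen; one six-membered non-aromatic ring with 2 hetero atoms), on a saturated chain carbon bound to a double-bonded ring carbon. The leaving group brings one hydrogen-bond donor, the entering group none, and the ring changes from six-membered to five-membered with the double bonds outside aromatic rings added. The step from compound 2 to compound 3 in this assay is expected to run downward and to exceed the scatter, with an estimated 3.6-fold lower number from compound 2 to compound 3 (0.55 log units; beyond the scatter). For compound 3 the expected value in this assay is 70 ug/mL, within a range from 20 ug/mL to 200 ug/mL.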

Compound 3, solubility: 125 ug/mL
Compound 3: the middle estimate sits 1.8-fold (0.25 log units) below what was measured; low and high end bracket the measured number.
By their numbers in this assay, from the lowest: compounds 1, 3 and 2 (each within the scatter of the next, the first and the last beyond it).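

In this assay, for the compounds shown here, the pair gives the first step that can be read between compounds differing in one place, and that step is a 2.0-fold lower number from compound 2 to compound 3 (0.30 log units; within the scatter) on a saturated chain carbon bound to a double-bonded ring carbon. At this place, then, the five-membered non-aromatic ring holding nitrogen, sulfur and two oxygens and the piperazin-1-yl group give numbers that cannot be told apart in this measurement, even though the piperazin-1-yl group carries a hydrogen-bond donor and the entering group carries none. No measurement shown offers an explanation for how close these two numbers lie.

Going by these compounds alone, compound 1 differs from each of the other two compounds in more than one place, so no step to it can be read, and the contribution of any single group in it stays unresolved. Also open, from the compounds shown here alone, is whether morpholine, a carboxylic acid or a longer chain on this same carbon would give a step beyond the scatter, and whether the exchange seen here would read the same with a group other than fluorine on the outer aromatic ring.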